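The source may report more compounds than this note shows. Statements on the series, on what has been measured and on what is new or still open speak of the compounds shown alone.

Among the compounds with values here, in a functional assay on A2780 cells (Homo sapiens) for antiproliferative activity, read by MTT assay, with a stated time of 72 h (a higher number here means a weaker inhibitor, a lower number a stronger inhibitor), compound 1 (`COc1cc(/C=C\c2cc3cc(F)ccc3s2)cc(OC)c1OC`) gives 200 nM as the only actual number in this small set. Compound 3 (`COc1ccsc1/C=C\c1cc(OC)c(OC)c(OC)c1`) reads > 1000 nM as a limit of the assay, not a number. For compound 2 (`COc1ccc2sc(/C=C\c3cc(OC)c(OC)c(OC)c3)cc2c1`) the entry is "not determined" (no result reported) and offers nothing to compare. Compound 4 (`COc1cc(/C=C\c2cc3ccccc3s2)cc(OC)c1OC`) is still unmeasured and differs from compound 1 by a single swap (hydrogen in place of fluoro on an aromatic carbon), hydrogen in place of fluoro on an aromatic carbon. Within the data shown here, no measured pair shows what this swap does in this assay so the expected change is none beyond the usual scatter, in either direction. With compound 1 at 200 nM as the only anchor, the estimated step (a 1.1-fold higher number from compound 1 to compound 4 (0.04 log units; within the scatter)) is small. Compound 4 is estimated at 220 nM (expected range 70 nM to 700 nM).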

Compound 4, half-maximal inhibitory concentration: 7.9 nM
Compound 4: middle estimate off by 28-fold (1.44 log units), on the high side, and the stated range ends above it.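

Within the data shown here, putting hydrogen in place of fluoro on this aromatic carbon gives a 25-fold lower number from compound 1 to compound 4 (1.40 log units; beyond the scatter) in this assay, so a change of one atom at this place can move the number well beyond the scatter, which no earlier pair could show. Here, the compound without the fluoro is the stronger inhibitor. Nothing shown explains why the step is so large.

Compound 2 carries methoxy at this place but has no reported result, so that comparison cannot be read. Going by these compounds, whether an amine or a chloro group here would keep the activity of compound 4 remains open.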